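The source may report more compounds than this note shows. Statements on the series, on what has been measured and on what is new or still open speak of the compounds shown alone.

Measured so far, in an assay on isolated protein for inhibition of aldehyde dehydrogenase 1A1 (Homo sapiens), read by spectrophotometry, tested at 10 uM; on this read-out lower numbers stand for less inhibition and higher numbers for more inhibition at the one concentration tested (going by the name of the read-out):
compound 1 `Cc1cccc(Cn2c(CN3CCN(C(=O)c4ccc(C(C)C)cc4)CC3)nc3ccccc32)c1` gives 67.6%
compound 2 `Cc1cccc(Cn2c(CN3CCN(C(=O)c4cccs4)CC3)nc3ccccc32)c1` gives 60.8%
compound 3 `Cc1cccc(Cn2c(CN3CCN(C(=O)C4CCCCC4)CC3)nc3ccccc32)c1` gives 31.9%

Compound 3 stands lowest of the three, with compound 2 nearest a number 28.9 percentage points lower from compound 2 to compound 3 (beyond the scatter) and compound 1 furthest a number 35.7 percentage points lower from compound 1 to compound 3 (beyond the scatter). Both steps run in the same direction: exchanging a flat ring on the carbonyl carbon for cyclohexyl costs a clear portion of inhibition, while the swap between the two flat rings a number 6.8 percentage points lower from compound 1 to compound 2 (within the scatter) stays within the scatter.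

Compound 4 `Cc1cccc(Cn2c(CN3CCN(C(=O)C4CCCC4)CC3)nc3ccccc32)c1` differs from compound 3 in one place (cyclopentyl in place of cyclohexyl on a carbonyl carbon). This is a smaller change than any of the measured steps: a non-aromatic carbon ring stays a non-aromatic carbon ring, only shrunk by one member. Going by the values given here, no measured pair shows what such a shrinking does, so the measured steps give only indirect guidance. Since the larger exchanges that moved the numbers all concerned losing an aromatic ring, and compound 4 keeps the non-aromatic ring of compound 3, a step within the scatter is expected, a number 1.9 percentage points lower from compound 3 to compound 4 (within the scatter). Compound 4 is therefore estimated at 30%, somewhere between 15% and 45%.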

Compound 4, a percentage reported as inhibition, at one concentration (the size of the read-out at that concentration, not a potency): 67.5%
Beside the measured number, compound 4's estimate is 37.5 percentage points below it, outside the stated range (above it).
By their numbers in this assay, from the lowest: compound 3; then compounds 2, 4 and 1 (each within the scatter of the next).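

In this assay, shrinking the non-aromatic carbon ring on the carbonyl carbon by one member is enough to shift the result, with cyclopentyl in place of cyclohexyl giving a number 35.6 percentage points higher from compound 3 to compound 4 (beyond the scatter). An aromatic ring is therefore not needed here for this level of inhibition: the step of a number 6.7 percentage points higher from compound 2 to compound 4 (within the scatter) and the step of a number 0.1 percentage points lower from compound 1 to compound 4 (within the scatter) both lie within the scatter, which leaves the cyclohexyl compound 3 as the one that stands apart. Nothing available explains why two such similar rings behave so differently.

Still open, as far as these compounds go, is how a smaller cyclobutyl or cyclopropyl ring, or an open chain such as isopropyl, would fare on this carbonyl carbon. Results at a single concentration also leave open how the potencies of these compounds compare.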